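Moving the methyl around the ring in a capsaicin receptor antagonist series

A few compounds are considered here, and "the series" means these few. Any claim that something is new, unique, unknown or untested is made for them only; others in the source may bear on it.

Measured compounds:
- compound 1, `CS(=O)(=O)Nc1ccc(C(C(=O)NCc2ccc(C(F)(F)F)nc2SC2CCCCC2)c2ccc(F)cc2)cc1F`: 37.6 nM
- compound 2, `Cc1ccccc1C(C(=O)NCc1ccc(C(F)(F)F)nc1SC1CCCCC1)c1ccc(NS(C)(=O)=O)c(F)c1`: "active" (no number reported)

Both compounds were tested in an assay on CHO cells for antagonist activity at transient receptor potential cation channel subfamily V member 1 (Homo sapiens), read by FLIPR; a lower number here means a stronger inhibitor, a higher number a weaker inhibitor. Compound 1 gives 37.6 nM. Compound 2 was reported only as "active" (no number reported), so no single number places it on the scale, and the gap between compound 1 and compound 2 cannot be sized.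

The next compound, compound 3 `Cc1ccc(C(C(=O)NCc2ccc(C(F)(F)F)nc2SC2CCCCC2)c2ccc(NS(C)(=O)=O)c(F)c2)cc1`, keeps every atom of compound 2 and differs only in how they are joined: 4-methylphenyl in place of 2-methylphenyl on a saturated chain carbon bound to an aromatic carbon and a carbonyl carbon.

Within the data shown here, with no measured step for this kind of change available, the expectation is a modest one: in this assay compound 3 is expected to land within the usual scatter of where compound 1 stands, in no firm direction. Compound 3 is therefore estimated at 50 nM, with a plausible range from 12 nM to 250 nM.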

Compound 3, inhibition constant: 7.5 nM
The estimate for compound 3 lay 6.7-fold (0.82 log units) above the measured number; measured number below the stated range.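

In this assay, methyl in place of fluoro on an aromatic carbon gives a 5.0-fold lower number from compound 1 to compound 3 (0.70 log units; beyond the scatter), so compound 3 is the stronger inhibitor of this pair. This ring carbon therefore responds to the choice of group, and the 4-methylphenyl ring of compound 3 does better here than the fluoro-bearing ring of compound 1. Nothing shown here gives a reason for this gain.

Compound 2 carries only the word "active", so the step to compound 3 cannot be read, and the effect of moving the methyl from the 2-methylphenyl to the 4-methylphenyl arrangement remains unsized. Also open, as far as these compounds go, is how a chlorine atom, a methoxy group or a longer chain such as ethyl would compare with methyl on that same aromatic carbon.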